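This account rests on a few compounds, and the source may have more. Where it says the series, first, only, none or still open, it means among the compounds named here.

Values in a functional assay on HeLa cells (Homo sapiens) for antiproliferative activity, read by MTT assay, with a stated time of 72 h; on this read-out higher numbers stand for weaker inhibition and lower numbers for stronger inhibition:

- compound 1 `COc1cc(C(=O)c2sc3ccccc3c2-c2ccc(Cl)cc2)cc(OC)c1OC`: 5200 nM
- compound 2 `COc1ccc(-c2c(C(=O)c3cc(OC)c(OC)c(OC)c3)sc3ccccc23)c(OC)c1`: 3900 nM
- compound 3 `COc1cc(C(=O)c2sc3ccccc3c2Nc2ccccc2)cc(OC)c1OC`: 2700 nM

Compound 3 does not separate from the other two compounds. Its steps, a 1.9-fold lower number from compound 1 to compound 3 (0.28 log units; within the scatter) and a 1.4-fold lower number from compound 2 to compound 3 (0.16 log units; within the scatter), are both within the scatter, so the three values are best read as one level of activity.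

Compound 4 `COc1cc(C(=O)c2sc3ccccc3c2Nc2ccc(Cl)cc2)cc(OC)c1OC` is compound 3 with one addition: chloro in place of hydrogen on an aromatic carbon. This is chloro in place of hydrogen on an aromatic carbon, para to a large group.

Among the measured compounds shown here, no measured pair shows this change on its own. The closest evidence comes from swapping the whole group on the shared core. That gave a 1.3-fold lower number from compound 1 to compound 2 (0.12 log units; within the scatter) as well as the two steps to compound 3, and all of these stayed within the scatter. Compound 1 already carries a 4-chlorophenyl group and has a value of 5200 nM, which gives no sign that chlorine shifts the number far.

No step beyond the scatter is therefore expected, and the estimated change is a 1.0-fold higher number from compound 3 to compound 4 (0.02 log units; within the scatter). For compound 4 the expected value is 2800 nM, with an estimated range of 1000 nM to 7500 nM.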

Compound 4, half-maximal inhibitory concentration: 3700 nM
Beside the measured number, compound 4's estimate is 1.3-fold (0.12 log units) below it; the measured number falls inside the stated range.
By their numbers in this assay, from the lowest: compounds 3, 4, 2 and 1 (each within the scatter of the next).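

Chloro in place of hydrogen on the aromatic carbon para to a large group can now be read on its own in this assay: the step is a 1.4-fold higher number from compound 3 to compound 4 (0.14 log units; within the scatter) and stays at one level of activity. The comparisons that replace the whole group on the shared core agree, with a 1.1-fold lower number from compound 2 to compound 4 (0.02 log units; within the scatter) and a 1.4-fold lower number from compound 1 to compound 4 (0.15 log units; within the scatter) both showing that compound 4 joins the other three at that same level. Nothing measured here offers an explanation for this result.

From the compounds shown here alone, it remains open whether a carboxylic acid, an amine or a longer alkyl chain at this position would move the number beyond the scatter. The compounds shown also leave open whether chloro would give the same result on another carbon of this ring.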